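Swapping a butylcyclohexyl group for cyano in a thiourea

The source may hold more compounds than are shown below. What is called first, only, known or untested is meant among the compounds shown, and "the series" means these compounds.

Compound 1 `CC[C@H]1CC[C@H](c2ccc(NC(=S)Nc3cccc(C(F)(F)F)c3)cc2)CC1`: 9000 nM
Compound 2 `CCCC[C@H]1CC[C@H](c2ccc(NC(=S)Nc3cccc(C(F)(F)F)c3)cc2)CC1`: 10000 nM
Compound 3 `N#Cc1ccc(NC(=S)Nc2cccc(C(F)(F)F)c2)cc1`: not yet measured

In an ADME assay on MDBK cells (Bos taurus) for cytotoxicity, read by MTT assay, with a stated time of 96 h (a lower number here means that less compound is tolerated, a higher number that more compound is tolerated), compound 2 gives 10000 nM, and compound 1 gives 9000 nM. These two values lie within the usual scatter of each other, so neither compound can be said to stand apart.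

The next structure makes a much larger change, with cyano in place of 4-butylcyclohexyl on an aromatic carbon.

Among the measured compounds shown here, only one measured step bears on this change, and it is a weak guide. a 1.1-fold higher number from compound 1 to compound 2 (0.05 log units; within the scatter) alters only the chain on the saturated ring and leaves that ring in place. For the measured compounds named here, no measured compound lacks the ring, so the size of the coming step is poorly known, and the range must stay wide. Tentatively, a higher number is expected in this assay, with an estimated 2.0-fold higher number from compound 2 to compound 3 (0.30 log units; within the scatter).

Compound 3 is estimated at 20000 nM, with an expected range from 5000 nM to 80000 nM.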

Compound 3, half-maximal cytotoxic concentration: 10000 nM
Estimate against measurement, compound 3: 2.0-fold (0.30 log units) above; low and high end bracket the measured number.
By their numbers in this assay, from the lowest: compounds 1, 2 and 3 (each within the scatter of the next).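

In this assay, replacing the whole 4-butylcyclohexyl group with cyano on this aromatic carbon gives no change at the digits printed from compound 2 to compound 3 (within the scatter), and replacing 4-ethylcyclohexyl with cyano gives a 1.1-fold higher number from compound 1 to compound 3 (0.05 log units; within the scatter). The earlier pair differed only in the chain on the saturated ring, whereas compound 3 lacks that ring altogether, so this result tests a far larger swap: a group of 10 heavy atoms gives way to one of 2, and the three compounds still cannot be told apart in this assay. No measurement shown here offers an explanation for this result.

On these data alone, whether an amine or a carboxylic acid on the same aromatic carbon would also stay within the scatter, or would shift the tolerated concentration beyond it, remains open. Also open, as far as these compounds go, is whether the level of cytotoxicity seen in all three compounds is set by the shared core rather than by the group at this position.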